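Methyl on Sulfur: a Step Taken from a Limit

The source may hold more compounds than are shown below. What is called first, only, known or untested is meant among the compounds shown, and "the series" means these compounds.

Compound 2 `CCCc1ncc2cnnc(S)n12` is known in a functional assay for inhibition, with Homo sapiens as the target (a lower number here means a stronger inhibitor, a higher number a weaker inhibitor), only as a limit. In this assay compound 2 gives > 48000 nM, which is a limit of the assay and not a number. Compound 3 `Cc1ncc2cnnc(S)n12` gives > 48000 nM, also a limit. Compound 1 `CCCc1nc(C)c2cnnc(SC)n12` gives > 48000 nM, again a limit. For the measured compounds named here, the one step between measured compounds, a step that the two limits leave unreadable from compound 2 to compound 3, therefore cannot be read in size or direction. Compound 4 `CCCc1ncc2cnnc(SC)n12` differs from compound 2 by methyl in place of hydrogen on a sulfur. Going by the values given here, every measured value sits at the limit of > 48000 nM in this assay, at which 3 of the 3 values shown sit, so no measured step gives a size or a direction for this change. Compound 4 is expected to give 60000 nM, with a range from 15000 nM to 250000 nM. The expected step that the limit leaves unreadable from compound 2 to compound 4 is thus one the assay is unlikely to show beyond its limit.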

Compound 4, half-maximal inhibitory concentration: > 48000 nM
Compound 4: no number, only a limit (the forecaster's own chance of this, stated with the estimate: 85%); the middle value lies beyond the limit too.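

Compound 4, like compound 1 and compound 2, gives only a limit in this assay, so no new step can be read: the limit of > 48000 nM in this assay, at which 4 of the 4 values shown sit. The compounds shown leave open whether either methyl change alters inhibition at all.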